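The source may hold more compounds than are shown below. What is called first, only, known or untested is meant among the compounds shown, and "the series" means these compounds.

In a physicochemical assay for lipophilicity, read by mass spectrometry (a lower number here means a more polar compound, a higher number a more lipophilic compound), compound 1 `COc1cc2c(cc1OC)C(=O)C(C(=O)Nc1cccc(Cl)c1)C2` gives 2.76 and compound 2 `COc1cc2c(cc1OC)C(=O)C(C(=O)Nc1ccccc1C)C2` gives 2.69 so the two stand level within the usual scatter. Compound 3 `CCOc1ccccc1NC(=O)C1Cc2cc(OC)c(OC)cc2C1=O` keeps the shared core of compound 2 and carries one change: ethoxy in place of methyl on an aromatic carbon in words, ethoxy in place of methyl on an aromatic carbon. Among the compounds with values here, only one measured step exists, and a number 0.07 log units lower from compound 1 to compound 2 (within the scatter) is a different exchange, so it gives only a weak guide. The expected change is a number 0.11 log units higher from compound 2 to compound 3 (within the scatter) in this assay with no shift beyond the scatter expected. Compound 3 is therefore estimated at 2.8 with 2.4 to 3.2 as its expected range.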

Compound 3, partition coefficient: 2.42
Beside the measured number, compound 3's estimate is 0.38 log units above it; low and high end bracket the measured number.
By their numbers in this assay, from the lowest: compounds 3, 2 and 1 (each within the scatter of the next, the first and the last beyond it).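

In this assay, ethoxy in place of methyl on an aromatic carbon, ortho to a large group, gives a number 0.27 log units lower from compound 2 to compound 3 (within the scatter) for this exchange. So this place on the ring can take ethoxy, with its added oxygen and larger size, and the number stays within the scatter of the methyl compound. No measurement shown offers a reason for this result. Going by these compounds, whether an amine or a carboxylic acid on this same carbon would move the number beyond the scatter remains open, and so does the effect of a longer chain such as butoxy.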